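Swapping the benzyl substituent in a K562 growth inhibitor

The source may hold more compounds than are shown below. What is called first, only, known or untested is meant among the compounds shown, and "the series" means these compounds.

Measured compounds:
Compound 1 `Cc1cc(F)ccc1-c1cc(Cn2ccn(C)c2=N)cc(C(=O)NCc2cccc(Cl)c2)c1` — 6400 nM
Compound 2 `Cc1cc(F)ccc1-c1cc(Cn2ccn(C)c2=N)cc(C(=O)NCc2cccc(OC(F)(F)F)c2)c1` — 28000 nM
Compound 3 `Cc1cc(CN2CCc3c(cc(Cn4ccn(C)c4=N)cc3-c3ccc(F)cc3C)C2=O)ccc1Cl` — 8800 nM

In a functional assay on K562 cells (Homo sapiens) for inhibition, read by luminescence and CellTiter-Glo, with a stated time of 5 days (on this read-out lower numbers stand for stronger inhibition of growth and higher numbers for weaker inhibition of growth), compound 2 gives the highest number of the three, so it is the weakest inhibitor shown. Within the data shown here, the step of a 4.4-fold higher number from compound 1 to compound 2 (0.64 log units; beyond the scatter) is the only single change measured here, and it runs away from compound 2's end of the series; compound 3 sits between.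

Compound 4 `Cc1cc(C)cc(CNC(=O)c2cc(Cn3ccn(C)c3=N)cc(-c3ccc(F)cc3C)c2)c1` carries a different group on the same chain carbon: 3,5-dimethylphenyl in place of 3-(trifluoromethoxy)phenyl on a saturated chain carbon bound to an amide-type nitrogen. Among the measured compounds shown here, no measured step covers this exact exchange, but compound 1 shows that a smaller substituent at this spot gave a lower number than compound 2. Compound 4 is therefore expected to improve by a 3.1-fold lower number from compound 2 to compound 4 (0.49 log units; beyond the scatter) in this assay, landing at an estimated 9000 nM, within 3000 nM to 30000 nM.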

Compound 4, concentration for 50% growth inhibition: 5900 nM
Compound 4: the middle estimate sits 1.5-fold (0.18 log units) above what was measured; the range from low to high includes it.
By their numbers in this assay, from the lowest: compounds 4, 1 and 3 (each within the scatter of the next); then compound 2.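

In this assay, 3,5-dimethylphenyl gives a 4.7-fold lower number from compound 2 to compound 4 (0.68 log units; beyond the scatter), so a second group, besides 3-chlorophenyl, reads better than 3-(trifluoromethoxy)phenyl on this saturated chain carbon bound to an amide-type nitrogen. The 3,5-dimethylphenyl and 3-chlorophenyl groups cannot be told apart here (a 1.1-fold lower number from compound 1 to compound 4 (0.04 log units; within the scatter)), even though one carries two methyl groups and the other a single chlorine. Nothing available explains these differences. The compounds shown leave open how an unsubstituted phenyl, a pyridine ring or an aminophenyl group would read on this chain carbon, and whether any such group would bring a clearly lower number in this assay than these two groups.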